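Furan-2-yl in Place of Pyridin-2-yl: an Expected Gain

The source may hold more compounds than are shown below. What is called first, only, known or untested is meant among the compounds shown, and "the series" means these compounds.

Measured compounds:
compound 1 `CN(C)c1ccc(Nc2nccc(-c3ccco3)n2)cc1` gives 1900 nM
compound 2 `Cc1cc(-c2ccccn2)nc(Nc2ccc(N(C)C)cc2)n1` gives 31900 nM
compound 3 `CC1CCN(c2ccc(Nc3nccc(-c4cccs4)n3)cc2)CC1` gives 400 nM

All three were tested in a functional assay for inhibition, with Homo sapiens as the target; on this read-out lower numbers stand for stronger inhibition and higher numbers for weaker inhibition. Among them compound 2 stands at the highest number, meaning the weakest inhibition of the three. Its nearest neighbour is compound 1, whose number is lower by a margin that lies beyond the usual scatter, and compound 3 lies lower still, also beyond the scatter.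

The next compound to consider is compound 4 `Cc1cc(-c2ccco2)nc(Nc2ccc(N(C)C)cc2)n1`, which has not yet been measured in this assay. It differs from compound 2 in one place: furan-2-yl in place of pyridin-2-yl on an aromatic carbon. Among the measured compounds shown here, because compound 1, which also carries a furan-2-yl group, gives 1900 nM while compound 2 gives 31900 nM, the change points toward a lower number, although compound 1 and compound 2 also differ elsewhere, so no single step between measured compounds pins down the size of this effect. A clear drop is nevertheless expected, larger than the scatter.

For compound 4 in this assay the estimate is 6000 nM, within a range from 1500 nM to 24000 nM, which corresponds to an expected step of a 5.3-fold lower number from compound 2 to compound 4 (0.73 log units; beyond the scatter).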

Compound 4, half-maximal inhibitory concentration: 5900 nM
Compound 4: middle estimate off by 1.0-fold (0.01 log units), on the high side, within the range that was stated.
By their numbers in this assay, from the lowest: compound 3; then compound 1; then compound 4; then compound 2.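

In this assay, the step from pyridin-2-yl to furan-2-yl on an aromatic carbon of the shared core can now be read directly, with the methyl group and the rest of the structure unchanged: it gives a 5.4-fold lower number from compound 2 to compound 4 (0.73 log units; beyond the scatter). Compound 4 also provides a second one-place comparison, since methyl in place of hydrogen on an aromatic carbon gives a 3.1-fold higher number from compound 1 to compound 4 (0.49 log units; beyond the scatter), so this small group also changes the read-out by more than the usual scatter. Together these steps show that the wide gap between the printed values of compound 1 and compound 2 cannot be assigned to the ring change alone, because the ring change and the methyl group each make a step beyond the scatter in opposite directions along this route.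

Nothing shown here gives a reason for either step. Going by these compounds, it remains open how a phenyl ring or an amine would compare with furan-2-yl on the same carbon, and whether an ethyl group in place of the methyl group would move the number further in the same direction.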